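The source may hold more compounds than are shown below. What is called first, only, known or untested is meant among the compounds shown, and "the series" means these compounds.

Working notes on the series. For the measured compounds named here, in a functional assay for activation of Alpha-1A adrenergic receptor (Homo sapiens), read by calcium flux (on this read-out lower numbers stand for an effect already at smaller amounts and higher numbers for an effect only at larger amounts of compound), compound 3 `c1ccc(-c2cnccn2)c(OCC2=NCCN2)c1` gives 2.51 nM, the only number among the three measured entries. Compound 1 `Cc1cccnc1-c1ccccc1OCC1=NCCN1` gives a limit in this assay, < 100000 nM, and not a number. Compound 2 `Cc1ccnc(-c2ccccc2OCC2=NCCN2)c1` likewise returns only a limit in this assay, < 100000 nM. Going by the values given here, two of the three measured entries therefore sit at the limit of < 100000 nM in this assay, at which 2 of the 3 values shown sit, so no step between measured compounds can be sized, and compound 3 stands alone as the single numbered value of the set.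

Compound 4 `c1ccc(-c2ncc[nH]2)c(OCC2=NCCN2)c1` has not yet been measured. It differs from compound 3 in one place: 1H-imidazol-2-yl in place of pyrazin-2-yl on an aromatic carbon. The change exchanges one six-membered aromatic ring with 2 hetero atoms for one five-membered aromatic ring with 2 hetero atoms, and brings 1 hydrogen-bond donor in place of a group with 0 hydrogen-bond donors.

Among the compounds with values here, no measured step covers a change of this kind, so the expectation rests on compound 3 alone. A step from compound 3 to compound 4 of a 6.0-fold higher number from compound 3 to compound 4 (0.78 log units; beyond the scatter) in this assay is expected, toward an effect only at larger amounts of compound, somewhat beyond the usual scatter but well short of the limit. Compound 4 is accordingly expected to give 15 nM in this assay, with a range from 2 nM to 150 nM.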

Compound 4, half-maximal effective concentration: 100 nM
Estimate against measurement, compound 4: 6.7-fold (0.82 log units) below; the range from low to high includes it.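

In this assay, for the compounds shown here, replacing pyrazin-2-yl with 1H-imidazol-2-yl on an aromatic carbon, ortho to a group of 7 heavy atoms, gives a 40-fold higher number from compound 3 to compound 4 (1.60 log units; beyond the scatter), the first step that can be sized and evidence that the read-out is sensitive to the group at this place. Going by these compounds alone, compound 4 nevertheless gives 100 nM, so a five-membered aromatic ring with 2 hetero atoms at this place still yields a number and not a limit, although the single change alters ring size, hydrogen-bond donor count and hydrogen-bond acceptor count together. Steps involving compound 1 or compound 2 cannot be read, as their entries are limits and not numbers: the limit of < 100000 nM in this assay, at which 2 of the 4 values shown sit.

The compounds shown leave open which part of the exchange carries the step, since ring size and the added hydrogen-bond donor arrive together in compound 4. A 1-methylimidazol-2-yl group on the same aromatic carbon would keep the five-membered ring while replacing the ring hydrogen on nitrogen with methyl, and so would help separate these two parts of the change.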